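This account rests on a few compounds, and the source may have more. Where it says the series, first, only, none or still open, it means among the compounds named here.

In a functional assay on KYSE-450 cells (Homo sapiens) for inhibition, read by CCK-8 assay, with a stated time of 48 h (on this read-out higher numbers stand for weaker inhibition and lower numbers for stronger inhibition), compound 3 (`COc1ccc(CN(C(=O)CSC(=S)N2CCOCC2)c2cc(OC)c(OC)c(OC)c2)cc1`) gives 7220 nM, the highest of the three numbers. Compound 1 (`CCN1CCN(C(=S)SCC(=O)N(Cc2ccc(OC)cc2)c2cc(OC)c(OC)c(OC)c2)CC1`) gives 3070 nM, and compound 2 (`COc1ccc(CN(C(=O)CSC(=S)N2CCN(C(C)=O)CC2)c2cc(OC)c(OC)c(OC)c2)cc1`) gives 370 nM.

Compound 4 (`CCN1CCN(CC(=O)N(Cc2ccc(OC)cc2)c2cc(OC)c(OC)c(OC)c2)CC1`) is the next to be read. Its change from compound 3 is a group of 8 heavy atoms (6 carbon, 2 nitrogen; one six-membered non-aromatic ring with 2 hetero atoms) in place of a group of 9 heavy atoms (5 carbon, 1 nitrogen, 1 oxygen, 2 sulfur; one six-membered non-aromatic ring with 2 hetero atoms), on a saturated chain carbon bound to a carbonyl carbon.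

The closest measured evidence is a 2.4-fold higher number from compound 1 to compound 3 (0.37 log units; beyond the scatter), where morpholin-4-yl replaces 4-ethylpiperazin-1-yl on a thiocarbonyl carbon. Taken in reverse, that modest step points to a somewhat lower number for a 4-ethylpiperazin-1-yl compound. However, all three measured compounds keep the thiocarbonyl carbon and both sulfur atoms, while compound 4 has neither, so no measured step tests that loss.

The other two steps bear on it less directly. an 8.3-fold lower number from compound 1 to compound 2 (0.92 log units; beyond the scatter) and a 20-fold higher number from compound 2 to compound 3 (1.29 log units; beyond the scatter) both involve the acetyl compound, and they show how far the numbers can move with changes in this part of the series.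

With the direction of the effect unknown, no step beyond the scatter is expected in this assay, and the uncertainty is wide in both directions. The expected result is a 1.2-fold lower number from compound 3 to compound 4 (0.08 log units; within the scatter). For compound 4 the estimated value is 6000 nM, with an expected range of 1500 nM to 25000 nM.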

Compound 4, half-maximal inhibitory concentration: 16100 nM
Compound 4: middle estimate off by 2.7-fold (0.43 log units), on the low side; the measured number falls inside the stated range.
By their numbers in this assay, from the lowest: compound 2; then compound 1; then compound 3; then compound 4.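

In this assay, within the data shown here, the step of a 5.2-fold higher number from compound 1 to compound 4 (0.72 log units; beyond the scatter) is the first reading of the loss of the thiocarbonyl carbon and the sulfur atoms with the 4-ethylpiperazin-1-yl group kept, and that loss goes with weaker inhibition. The other two readings point the same way: a 2.2-fold higher number from compound 3 to compound 4 (0.35 log units; beyond the scatter) and a 44-fold higher number from compound 2 to compound 4 (1.64 log units; beyond the scatter), so all three compounds that keep the thiocarbonyl carbon give lower numbers than compound 4, whichever ring they carry. Nothing measured here explains this shift.

Still open, going by these compounds, is whether the lower number that comes with 4-acetylpiperazin-1-yl in compound 2 survives when that ring sits directly on the saturated chain carbon bound to a carbonyl carbon. Also open, on these data alone, is which of the removed atoms matters, which a carbamate or thiocarbamate link in place of the sulfur-bearing unit, with 4-ethylpiperazin-1-yl kept, would begin to separate.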